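The compounds below may be only part of what the source reports. "The series", "measured", "known", "first", "only" and "open" are said of these compounds alone.

Compound 1 `Cc1noc(-c2cc3cc(F)ccc3[nH]2)n1`: 22900 nM
Compound 2 `Cc1noc(-c2cc3cc(Cl)ccc3[nH]2)n1`: 21600 nM
Compound 3 `COc1ccc(-c2noc(-c3cc4cc(F)ccc4[nH]3)n2)cc1`: > 50000 nM (a limit of the assay, not a number)

All three were tested in a functional assay on Jurkat cells (Homo sapiens) for antiproliferative activity, read by WST assay, with a stated time of 72 h; on this read-out lower numbers stand for stronger inhibition and higher numbers for weaker inhibition. Compound 1 gives 22900 nM. Compound 2 gives 21600 nM. Compound 3 reaches only a limit of the assay, > 50000 nM, which is the limit described in the limit of > 50000 nM in this assay, at which 1 of the 3 values shown sits. Compound 2 differs from compound 1 by one change, (chloro in place of fluoro on an aromatic carbon), and the step of a 1.1-fold lower number from compound 1 to compound 2 (0.03 log units; within the scatter), so the two values cannot be told apart. How the core of compound 3 differs from that of compound 1 is not broken down here. Compound 4 `COc1ccc(-c2noc(-c3cc4cc(Cl)ccc4[nH]3)n2)cc1`, not yet measured, stands to compound 3 as compound 2 stands to compound 1: the change is chloro in place of fluoro on an aromatic carbon, the same change in the same place. Because the earlier step of a 1.1-fold lower number from compound 1 to compound 2 (0.03 log units; within the scatter) stayed within the scatter, and because compound 3 in this assay sits at the limit > 50000 nM, compound 4 is expected to sit at or beyond the limit as well. The estimated step for compound 4 is a step that the limit leaves unreadable from compound 3 to compound 4. Compound 4 is therefore estimated at 70000 nM, with a range from 40000 nM to 150000 nM.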

Compound 4, half-maximal inhibitory concentration: > 50000 nM
Compound 4: no number, only a limit (the forecaster's own chance of this, stated with the estimate: 80%); the middle value is on the limit's open side.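

For the compounds shown here, measured in this assay compound 3 and compound 4 both stop at a limit of the assay rather than at a number, so no step between them can be read: the limit of > 50000 nM in this assay, at which 2 of the 4 values shown sit. The compounds shown leave open whether chloro in place of fluoro makes any difference on the core of compound 3.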